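Phenyl in Place of Butyl on the Ring Nitrogen

The source may hold more compounds than are shown below. What is called first, only, known or untested is meant among the compounds shown, and "the series" means these compounds.

Compound 1, `COc1ccccc1CSc1nc2cc(NC(=O)C3CC3)ccc2n1C(C)C`, in an assay on isolated protein for inhibition of Gonadotropin-releasing hormone receptor (Rattus norvegicus) (on this read-out higher numbers stand for weaker inhibition and lower numbers for stronger inhibition), gives > 10000 nM, a limit of the assay.
Compound 2, `COc1ccc(C(C)=O)cc1CSc1nc2cc(NC(=O)C3CC3)ccc2n1C(C)C`, gives in this assay > 10000 nM, again a limit.
Compound 3, `CCCCn1c(SCc2cc([N+](=O)[O-])ccc2OC)nc2cc(NC(=O)NC(C)(C)C)ccc21`, gives in this assay 330 nM.

Among the compounds with values here, compound 3 thus carries the only number; the other two values sit at the limit of > 10000 nM in this assay, at which 2 of the 3 values shown sit. Within the data shown here, the one measured step, a step that the two limits leave unreadable from compound 1 to compound 2, concerns acetyl on an aromatic carbon and is not readable between its limits, so nothing measured bears on the ring nitrogen. Compound 4, `COc1ccc([N+](=O)[O-])cc1CSc1nc2cc(NC(=O)NC(C)(C)C)ccc2n1-c1ccccc1`, differs from compound 3 by phenyl in place of butyl on an aromatic nitrogen. Among the measured compounds shown here, with no comparable step to draw on, compound 4 is expected to stay near compound 3, the estimated step being a 1.2-fold higher number from compound 3 to compound 4 (0.08 log units; within the scatter). Compound 4 is estimated at 400 nM, within 100 nM to 3000 nM.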

Compound 4, half-maximal inhibitory concentration: > 2600 nM
Compound 4 was reported as a limit; the forecaster's own chance of this, stated with the estimate: 15%; middle value at least 6.5-fold (0.81 log units) away from the limit.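

In this assay, within the data shown here, the substituent on this aromatic nitrogen proves to matter, which the earlier compounds could not show: phenyl in place of butyl gives an at least 7.8-fold higher number from compound 3 to compound 4 (0.89 log units; beyond the scatter). Compound 4 stands at a limit of the assay and not at a number, so the true size of the step stays unknown: the limit of > 2600 nM in this assay, at which 1 of the 4 values shown sits. Within the compounds shown, only this one pair speaks to the position.

From the compounds shown here alone, how much weaker compound 4 really is remains open. So does whether benzyl, or a chain longer than butyl, on this nitrogen would hold the inhibition of compound 3.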